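A few compounds are considered here, and "the series" means these few. Any claim that something is new, unique, unknown or untested is made for them only; others in the source may bear on it.

Working notes on the series: compound 1 (`CCOC(=O)C1=C(NN=C(C(C)=O)C(C)=O)Nc2[nH]nc(C)c2C1c1ccc(N(C)C)cc1`), compound 2 (`CCOC(=O)C1=C(N/N=C(\C#N)C(N)=O)Nc2[nH]nc(C)c2C1c1ccc(N(C)C)cc1`) and compound 3 (`CCOC(=O)C1=C(N/C=N/c2ccccn2)Nc2[nH]nc(C)c2C1c1ccc(N(C)C)cc1`) share a core and differ in the group on an amine nitrogen. In a functional assay on HepG2 cells (Homo sapiens) for inhibition, read by MTT assay, with a stated time of 48 h (a lower number here means a stronger inhibitor, a higher number a weaker inhibitor), compound 1 gives 8480 nM, compound 2 gives 48400 nM and compound 3 gives 26200 nM. Compound 3 sits with compound 2 at the weaker end of this small set, since the series shows a 1.8-fold lower number from compound 2 to compound 3 (0.27 log units; within the scatter). Compound 1 stands apart, with a 3.1-fold higher number from compound 1 to compound 3 (0.49 log units; beyond the scatter).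

The change to compound 4 (`CCOC(=O)C(=NNC1=C(C(=O)OCC)C(c2ccc(N(C)C)cc2)c2c(C)n[nH]c2N1)C(=O)OCC`) is a group of 12 heavy atoms (7 carbon, 1 nitrogen, 4 oxygen; no ring) in place of a group of 8 heavy atoms (6 carbon, 2 nitrogen; one six-membered aromatic ring with 1 hetero atom), on an amine nitrogen. The ring leaves, so compound 4 joins compound 1 and compound 2 in carrying a group with no ring on that nitrogen. Those two compounds do not agree with each other, as the series shows a 5.7-fold higher number from compound 1 to compound 2 (0.76 log units; beyond the scatter). Having no ring therefore does not settle the number, and compound 3 already lies within that span. A position inside the span is expected in this assay, leaning slightly towards compound 1 at 8480 nM.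

The expected step is a 1.6-fold lower number from compound 3 to compound 4 (0.21 log units; within the scatter), so nothing beyond the scatter is expected. For compound 4 the estimated value is 16000 nM, with an expected range of 6000 nM to 42000 nM.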

Compound 4, half-maximal inhibitory concentration: 80800 nM
Compound 4: the middle estimate sits 5.1-fold (0.70 log units) below what was measured; the measured number lies above the stated range.
By their numbers in this assay, from the lowest: compound 1; then compounds 3, 2 and 4 (each within the scatter of the next, the first and the last beyond it).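

Compound 4 shows that a larger group with no ring, at 12 heavy atoms, does not bring the number down on this amine nitrogen: a 3.1-fold higher number from compound 3 to compound 4 (0.49 log units; beyond the scatter) in this assay. It also lands level with compound 2, a 1.7-fold higher number from compound 2 to compound 4 (0.22 log units; within the scatter), so two groups with no ring that differ in size and in their hydrogen-bond acceptor counts give numbers that cannot be told apart here. For the compounds shown here, the step from the other group with no ring is far larger, a 9.5-fold higher number from compound 1 to compound 4 (0.98 log units; beyond the scatter), which leaves compound 1 as the only clearly stronger member of the four, with steps beyond the scatter to each of the others, and shows that lacking a ring does not by itself set the number at this position.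

Nothing shown gives a reason why compound 1 separates from compound 2, compound 3 and compound 4. Going by these compounds, it remains open whether a carboxylic acid or a plain amine in this place, on the same shared core, would fall nearer to compound 1 or nearer to compound 2 and compound 4.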